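A few compounds are considered here, and "the series" means these few. Any claim that something is new, unique, unknown or untested is made for them only; others in the source may bear on it.

Going by the values given here, in a functional assay on SK-OV-3 cells (Homo sapiens) for cytotoxicity (on this read-out lower numbers stand for stronger inhibition and higher numbers for weaker inhibition), compound 1 `C=C/C=C\[C@H](C)[C@H](OC(N)=O)[C@@H](C)[C@H](O)[C@@H](C)C/C(C)=C\[C@H](C)[C@@H](O)[C@@H](C)/C=C\CCc1ccc(C)c(F)c1` gives 1000 nM, the highest of the three numbers measured so far. Compound 2 `C=C/C=C\[C@H](C)[C@H](OC(N)=O)[C@@H](C)[C@H](O)[C@@H](C)C/C(C)=C\[C@H](C)[C@@H](O)[C@@H](C)/C=C\CCc1cccc(O)c1C` gives 270 nM, and compound 3 `C=C/C=C\[C@H](C)[C@H](OC(N)=O)[C@@H](C)[C@H](O)[C@@H](C)C/C(C)=C\[C@H](C)[C@@H](O)[C@@H](C)/C=C\CCc1cc(F)cc(F)c1` gives 360 nM. Compound 4 `C=C/C=C\[C@H](C)[C@H](OC(N)=O)[C@@H](C)[C@H](O)[C@@H](C)C/C(C)=C\[C@H](C)[C@@H](O)[C@@H](C)/C=C\CCc1cccc(OC)c1` has not been measured. It differs from compound 1 in one group on a saturated chain carbon: 3-methoxyphenyl in place of 3-fluoro-4-methylphenyl on a saturated chain carbon, two bonds along the chain from a double-bonded chain carbon. Two measured steps replace that same group, a 3.7-fold lower number from compound 1 to compound 2 (0.57 log units; beyond the scatter) and a 2.8-fold lower number from compound 1 to compound 3 (0.44 log units; beyond the scatter), and both are modest moves to a lower number. The gap between their end points, a 1.3-fold higher number from compound 2 to compound 3 (0.12 log units; within the scatter), lies within the scatter. Among the compounds with values here, no measured compound carries a methoxy group, so this comparison is only a rough guide. A similar modest move is expected, a 2.4-fold lower number from compound 1 to compound 4 (0.38 log units; beyond the scatter). For compound 4, the estimated value is 420 nM, with an expected range from 150 nM to 1100 nM.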

Compound 4, half-maximal inhibitory concentration: 370 nM
Compound 4: the middle estimate sits 1.1-fold (0.06 log units) above what was measured, within the range that was stated.
By their numbers in this assay, from the lowest: compounds 2, 3 and 4 (each within the scatter of the next); then compound 1.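

A third kind of ring substituent also beats the 3-fluoro-4-methylphenyl group of compound 1 (a 2.7-fold lower number from compound 1 to compound 4 (0.43 log units; beyond the scatter)), so all three replacements tested at this chain end give a lower number. The three replacements cannot be told apart, since both (a 1.0-fold higher number from compound 3 to compound 4 (0.01 log units; within the scatter)) and (a 1.4-fold higher number from compound 2 to compound 4 (0.14 log units; within the scatter)) lie within the scatter, even though their ring substituents differ. No measurement here explains why these groups behave alike. From the compounds shown here alone, whether a phenyl ring bearing an amine or a carboxylic acid would keep the number in this range remains open.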